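This account rests on a few compounds, and the source may have more. Where it says the series, first, only, none or still open, it means among the compounds named here.

Of the compounds shown here, three have been measured in a functional assay on L1210 cells (Mus musculus) for cytotoxicity; on this read-out lower numbers stand for stronger inhibition and higher numbers for weaker inhibition. Compound 1, `O=C(/C=C/C(=O)N1C/C(=C\c2ccccc2)C(=O)/C(=C/c2ccccc2)C1)Nc1ccccc1`, gives 3600 nM. Compound 2, `Cc1ccc(NC(=O)/C=C/C(=O)N2C/C(=C\c3ccc([N+](=O)[O-])cc3)C(=O)/C(=C/c3ccc([N+](=O)[O-])cc3)C2)cc1C`, gives 4900 nM. Compound 3, `CC(=O)c1ccc(NC(=O)/C=C/C(=O)N2C/C(=C\c3ccc([N+](=O)[O-])cc3)C(=O)/C(=C/c3ccc([N+](=O)[O-])cc3)C2)cc1`, gives 1400 nM.

Among these three numbers compound 1 holds the second highest. Its value and that of compound 2 lie within the usual scatter of each other, so no order between them can be claimed, whereas compound 3 gives a clearly lower number than compound 1.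

The compound to be followed is compound 4, `COc1ccc(NC(=O)/C=C/C(=O)N2C/C(=C\c3ccccc3)C(=O)/C(=C/c3ccccc3)C2)cc1`. It differs from compound 1 in one place: methoxy in place of hydrogen on an aromatic carbon. Cut one bond further out, this reads phenylcarbamoyl to (4-methoxyphenyl)carbamoyl on the shared core.

Within the data shown here, only one measured step touches the aryl group on the amide-type nitrogen: a 3.5-fold lower number from compound 2 to compound 3 (0.54 log units; beyond the scatter). That step swapped one substituted aryl for another on a core bearing nitro groups rather than the unsubstituted core of compound 1, and neither partner carried a methoxy group. It shows that a change here can move the number modestly, but it fixes no direction for methoxy. For compound 4 a small step is therefore expected, with no confident direction, namely a 1.2-fold lower number from compound 1 to compound 4 (0.08 log units; within the scatter). Compound 4 is estimated at 3000 nM in this assay, between 1200 nM and 8000 nM.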

Compound 4, half-maximal inhibitory concentration: 6800 nM
For compound 4 the middle estimate is 2.3-fold (0.36 log units) below the measured one; measured number inside the range.
By their numbers in this assay, from the lowest: compound 3; then compounds 1, 2 and 4 (each within the scatter of the next).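

In this assay, methoxy in place of hydrogen on an aromatic carbon, para to a large group, gives a 1.9-fold higher number from compound 1 to compound 4 (0.28 log units; within the scatter), so on the shared core this replacement cannot be told apart from hydrogen. Among these compounds, this is the first step at the aryl group on the amide-type nitrogen to be read on the core of compound 1; the only earlier step there, a 3.5-fold lower number from compound 2 to compound 3 (0.54 log units; beyond the scatter), was read on the core bearing nitro groups and lay beyond the scatter. No supporting data are available that would account for this result.

On these data alone, it remains open whether another group at this place on the core of compound 1, such as an amine, a carboxylic acid or a longer alkoxy chain, would give a number beyond the scatter of compound 1. The compounds shown also leave open whether methoxy would give a similarly small step on the core bearing nitro groups, since neither compound on that core carries it.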